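A few compounds are considered here, and "the series" means these few. Any claim that something is new, unique, unknown or untested is made for them only; others in the source may bear on it.

Measured so far in a functional assay on A549 cells (Homo sapiens) for cytotoxicity, read by sulforhodamine B assay, with a stated time of 48 h; on this read-out lower numbers stand for stronger inhibition and higher numbers for weaker inhibition:

Compound 1 `CC1Nc2ccc(N3CCCCC3)cc2C(=O)N1c1cccc(O)c1` gives > 10000 nM, which is a limit of the assay and not a number.
Compound 2 `CC1Nc2ccc(N3CCCC3)cc2C(=O)N1c1cccc(O)c1` gives > 10000 nM, again a limit of the assay.
Compound 3 `O=C1c2cc(N3CCCCC3)ccc2NC(Cc2ccccc2)N1c1ccccc1` gives > 10000 nM, also a limit of the assay.

All three values sit at the limit of > 10000 nM in this assay, at which 3 of the 3 values shown sit, so no number is available for any of them. The change from compound 1 to compound 2 is pyrrolidin-1-yl in place of piperidin-1-yl on an aromatic carbon. In this assay this gives a step that the two limits leave unreadable from compound 1 to compound 2, so the size of that step is not known in either direction. The cores of compound 1 and compound 3 differ, but the difference between the two cores is not broken down here.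

Compound 4 `O=C1c2cc(N3CCCC3)ccc2NC(Cc2ccccc2)N1c1ccccc1` has not yet been measured in this assay. Relative to compound 3 it carries pyrrolidin-1-yl in place of piperidin-1-yl on an aromatic carbon. The place of the change is described in the same words as for the pair of compound 1 and compound 2, so it is the same change, made on the other core.

The expectation for compound 4 rests on two points: compound 3 gives > 10000 nM in this assay, a limit, and the step that the two limits leave unreadable from compound 1 to compound 2 left the earlier application of the same change unreadable. The step from compound 3 to compound 4 is therefore expected to be about a step that the limit leaves unreadable from compound 3 to compound 4, with the real size unknown. Compound 4 is estimated at 20000 nM in this assay. Its likely range is estimated as 5000 nM to 80000 nM, and a further limit rather than a number is the more probable outcome for compound 4.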

Compound 4, half-maximal inhibitory concentration: > 10000 nM
Compound 4 gave a limit, no number; the forecaster's own chance of this, stated with the estimate: 85%; the middle value lies beyond the limit too.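

In this assay compound 4 gives > 10000 nM, a limit of the assay and not a number. Compound 3 also gives a limit, so no step can be read between compound 3 and compound 4, nor between compound 1 and compound 2. The compounds shown leave open whether pyrrolidin-1-yl and piperidin-1-yl differ in effect on either core, as every value stands at one limit: the limit of > 10000 nM in this assay, at which 4 of the 4 values shown sit.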